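The source may hold more compounds than are shown below. What is called first, only, known or untested is meant among the compounds shown, and "the series" means these compounds.

Measured so far:
Compound 1 `CCC(=O)N(Cc1ccc(OC)c(O)c1)c1cc(OC)c(OC)c(OC)c1` — in a functional assay on HCT-116 cells (Homo sapiens) for inhibition, read by MTT assay, with a stated time of 48 h (a lower number here means a stronger inhibitor, a higher number a weaker inhibitor), compound 1 gives 61 nM.
Compound 2 `COc1ccc(CN(C(=O)CN=[N+]=[N-])c2cc(OC)c(OC)c(OC)c2)cc1O` — in this assay compound 2 gives 410 nM.

Of these two numbers, compound 2 holds the higher one and is thus the weaker inhibitor. Going by the values given here, the single measured step, a 6.7-fold higher number from compound 1 to compound 2 (0.83 log units; beyond the scatter), shows that changing the group on the carbonyl carbon can shift the number well beyond the scatter. Compound 3 `COc1ccc(CN(C(=O)/C=C/CBr)c2cc(OC)c(OC)c(OC)c2)cc1O` is not yet measured. It differs from compound 2 in one place: 3-bromoprop-1-en-1-yl in place of azidomethyl on a carbonyl carbon. Among the compounds with values here, no measured step covers this exact exchange; the step from compound 1 to compound 2 touches the same carbonyl position but a different pair of groups, so it marks the position as sensitive without giving a direction. The estimate for compound 3 is therefore wide, sitting between the two measured numbers, at 150 nM (range 40 nM to 600 nM), which means an expected step of a 2.7-fold lower number from compound 2 to compound 3 (0.44 log units; beyond the scatter).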

Compound 3, half-maximal inhibitory concentration: 59 nM
Beside the measured number, compound 3's estimate is 2.5-fold (0.41 log units) above it, within the range that was stated.
By their numbers in this assay, from the lowest: compounds 3 and 1 (each within the scatter of the next); then compound 2.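

The carbonyl position does not only lose activity: exchanging azidomethyl for 3-bromoprop-1-en-1-yl in this assay gives a 6.9-fold lower number from compound 2 to compound 3 (0.84 log units; beyond the scatter) and so shows that this position can shift the number in either direction. Set against ethyl, the same group gives a 1.0-fold lower number from compound 1 to compound 3 (0.01 log units; within the scatter) and cannot be told apart from it here, which leaves azidomethyl as the only one of the three groups that stands apart. Nothing shown gives a reason for these shifts.

The bromine and the double bond of 3-bromoprop-1-en-1-yl enter together, so the part each plays remains unresolved. From the compounds shown here alone, it also remains open how an amine, a carboxylic acid or a longer chain on this carbonyl carbon would compare with ethyl and 3-bromoprop-1-en-1-yl.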